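Bromo in place of hydrogen on compound 2

A few compounds are considered here, and "the series" means these few. Any claim that something is new, unique, unknown or untested is made for them only; others in the source may bear on it.

Measured in a functional assay on K-562R cells (Homo sapiens) for cytotoxicity, read by MTT assay, with a stated time of 48 h; on this read-out lower numbers stand for stronger inhibition and higher numbers for weaker inhibition:
- Compound 1 `COc1cc(-n2c(-c3ccc(O)cc3)c[nH]c2=O)cc(OC)c1OC`: > 50000 nM (a limit of the assay, not a number)
- Compound 2 `COc1cc(-n2c(-c3ccccc3)cn(C(C)=O)c2=O)cc(OC)c1OC`: 9600 nM

Among the measured compounds shown here, compound 2 carries the only numerical result in this assay so far, at 9600 nM. With just one number available, there is no measured range in which to place it. The sole other result is the limit recorded for compound 1.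

Next in line is compound 3 `COc1cc(-n2c(-c3ccc(Br)cc3)cn(C(C)=O)c2=O)cc(OC)c1OC`, which has not yet been measured. It replaces hydrogen with bromo on an aromatic carbon of compound 2, turning phenyl into 4-bromophenyl: bromo in place of hydrogen on an aromatic carbon.

For the measured compounds named here, no measured pair isolates this change, so any expectation is only loosely grounded. A modest shift towards stronger inhibition is expected, perhaps only slightly beyond the usual scatter, and the opposite direction cannot be ruled out. The anchor is compound 2 at 9600 nM. The estimated change is a 1.7-fold lower number from compound 2 to compound 3 (0.24 log units; within the scatter). For compound 3 the expected value is 5500 nM, with an estimated range of 1500 nM to 20000 nM.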

Compound 3, half-maximal inhibitory concentration: 900 nM
Estimate against measurement, compound 3: 6.1-fold (0.79 log units) above; the measured number lies below the stated range.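

In this assay, among the compounds shown here, bromo in place of hydrogen on the aromatic carbon gives the first single-change reading, turning phenyl into 4-bromophenyl: an 11-fold lower number from compound 2 to compound 3 (1.03 log units; beyond the scatter). The step is large, so this position, para to a large group, responds clearly to what it carries, and one added heavy atom is enough to move the read-out beyond the scatter. Nothing on hand speaks to the cause of this step.

The compounds shown have only hydrogen and bromo at this position on the acetyl-bearing core, so it remains open whether chloro, methoxy or an amine there would give a step of similar size or direction, and whether bromo alone accounts for it. Compound 1 stands at a limit of the assay, > 50000 nM, and differs from compound 2 in more than one place, so it leaves open whether the bromo step would carry over to a core without the acetyl group.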